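Fluoro in place of methyl: outlook for compound 4

A few compounds are considered here, and "the series" means these few. Any claim that something is new, unique, unknown or untested is made for them only; others in the source may bear on it.

Measured so far in an assay on HEK293 cells for inhibition of N-acylethanolamine-hydrolyzing acid amidase (Rattus norvegicus), read by LC-MS, with a stated time of 30 min; on this read-out lower numbers stand for stronger inhibition and higher numbers for weaker inhibition:
compound 1 `O=C(CCCCCCc1cccc(Cl)c1)N1CCCC1` gives 3700 nM
compound 2 `Cc1ccccc1-c1ccc(CCC(=O)N2CCCC2)cc1` gives > 100000 nM
compound 3 `Cc1ccc(-c2ccc(CCC(=O)N3CCCC3)cc2)cc1` gives 33200 nM.

For compound 2 the reported value is only a limit of this assay, namely (the limit of > 100000 nM in this assay, at which 1 of the 3 values shown sits). Among the two numbers given, compound 3 has the higher one; compound 1 sits lower, and that gap lies beyond the scatter. For the measured compounds named here, the one single-change step, an at least 3.0-fold lower number from compound 2 to compound 3 (0.47 log units; beyond the scatter), shows that moving the methyl alters the number, though its size is bounded by the limit on compound 2.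

Compound 4 `O=C(CCc1ccc(-c2ccc(F)cc2)cc1)N1CCCC1` differs from compound 3 only by fluoro in place of methyl on an aromatic carbon. Going by the values given here, no measured step exchanges methyl for fluoro at this position, so nothing here sets the direction. The expectation is that this small change stays within the scatter, the step of a 1.1-fold lower number from compound 3 to compound 4 (0.04 log units; within the scatter) being expected as essentially none. Compound 4 is therefore estimated at 30000 nM, with a range from 10000 nM to 100000 nM in this assay.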

Compound 4, half-maximal inhibitory concentration: 3400 nM
Compound 4: middle estimate off by 8.8-fold (0.95 log units), on the high side; the whole stated range lies above it.
By their numbers in this assay, from the lowest: compounds 4 and 1 (each within the scatter of the next); then compound 3. At a limit, above all of these: compound 2.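

In this assay, the position para to a large group responds to which group it carries, not only to where a methyl sits: with the place held fixed, fluoro in place of methyl gives a 9.8-fold lower number from compound 3 to compound 4 (0.99 log units; beyond the scatter). The wider exchange of 4-fluorophenyl in place of 2-methylphenyl gives an at least 29-fold lower number from compound 2 to compound 4 (1.46 log units; beyond the scatter). The value of compound 2 is a limit, so that step is only a bound: the limit of > 100000 nM in this assay, at which 1 of the 4 values shown sits.

On these data alone, whether the step reflects fluoro itself or the loss of methyl stays open, since only these two groups are compared at this position. Also open, as far as these compounds go, are how chloro, methoxy, an amine or a carboxylic acid at this position would compare with fluoro, and whether fluoro gives a similar step with a longer chain before the carbonyl.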